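Working notes: 3-acetylphenyl on the double-bonded nitrogen

The source may hold more compounds than are shown below. What is called first, only, known or untested is meant among the compounds shown, and "the series" means these compounds.

Measured in a functional assay on HepG2 cells (Homo sapiens) for cytotoxicity, read by sulforhodamine B assay, with a stated time of 24 h; a lower number here means a stronger inhibitor, a higher number a weaker inhibitor:
- compound 1 `O=C1Nc2ccc(S(=O)(=O)N3CCOCC3)cc2/C1=N/c1ccc(O)cc1`: 10400 nM
- compound 2 `Cc1ccc(S(=O)(=O)N/N=C2\C(=O)Nc3ccc(S(=O)(=O)N4CCOCC4)cc32)cc1`: 24700 nM
- compound 3 `CC(=O)N/N=C1\C(=O)Nc2ccc(S(=O)(=O)N3CCOCC3)cc21`: 27500 nM

Compound 3, at 27500 nM, sits level with compound 2 at the high end of this small set. The measured steps are a 1.1-fold higher number from compound 2 to compound 3 (0.05 log units; within the scatter) and a 2.6-fold higher number from compound 1 to compound 3 (0.42 log units; beyond the scatter).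

Compound 4 `CC(=O)c1cccc(/N=C2\C(=O)Nc3ccc(S(=O)(=O)N4CCOCC4)cc32)c1` carries 3-acetylphenyl in place of acetamido on a double-bonded nitrogen.

The step that bears most directly is a 2.6-fold higher number from compound 1 to compound 3 (0.42 log units; beyond the scatter), which puts acetamido in place of 4-hydroxyphenyl at that same place. Read backwards, it suggests that a phenyl group there may give a modest move to a lower number in this assay. The step of a 1.1-fold higher number from compound 2 to compound 3 (0.05 log units; within the scatter) concerns a change on an amine nitrogen and adds little. Among the compounds with values here, no measured compound carries 3-acetylphenyl, so the expectation is loose.

The expected step is a 2.3-fold lower number from compound 3 to compound 4 (0.36 log units; beyond the scatter).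

The estimate for compound 4 is 12000 nM, with an expected range of 5000 nM to 28000 nM.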

Compound 4, half-maximal inhibitory concentration: 28600 nM
Compound 4: middle estimate off by 2.4-fold (0.38 log units), on the low side, and the stated range ends below it.
By their numbers in this assay, from the lowest: compound 1; then compounds 2, 3 and 4 (each within the scatter of the next).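

A ring on the double-bonded nitrogen does not by itself give a lower number: in this assay, 3-acetylphenyl in place of acetamido leaves the value within the scatter (a 1.0-fold higher number from compound 3 to compound 4 (0.02 log units; within the scatter)), although the entering group is larger and carries a six-membered aromatic ring. The aryl group itself matters, since 3-acetylphenyl in place of 4-hydroxyphenyl gives a modest rise beyond the scatter (a 2.8-fold higher number from compound 1 to compound 4 (0.44 log units; beyond the scatter)). Among these groups at this place, only the 4-hydroxyphenyl of compound 1 stands apart, and compounds 2, 3 and 4 remain level.

The shown compounds leave open whether the hydroxyl group or its ring position separates compound 1, and 3-hydroxyphenyl, 4-acetylphenyl or 4-aminophenyl at this place would help to tell these apart. No supporting measurement explains the difference between these aryl groups.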